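Piperidine acyl variation in a naphthalenesulfonamide series

This account rests on a few compounds, and the source may have more. Where it says the series, first, only, none or still open, it means among the compounds named here.

Of the compounds shown here, two have been measured in an assay on L1.2 cells for binding affinity to C-C chemokine receptor type 8 (Homo sapiens); a lower number here means a stronger inhibitor, a higher number a weaker inhibitor. Compound 1 `CCOC(=O)N1CCC(NS(=O)(=O)c2ccc(OC(=O)c3ccccc3)c3ccccc23)CC1` gives 16.4 nM in this assay. Going by the values given here, compound 2 `CCC(=O)N1CCC(NS(=O)(=O)c2ccc(NC(=O)c3ccccc3C)c3ccccc23)CC1` gives 2.5 nM in this assay, the lower of the two numbers and the stronger inhibitor of the pair; the two structures differ in several places at once, so no single step connects them. Compound 3 `Cc1ccccc1C(=O)Nc1ccc(S(=O)(=O)NC2CCN(C(=O)C3CCCC3)CC2)c2ccccc12` is not yet measured. It differs from compound 2 in one place: cyclopentyl in place of ethyl on a carbonyl carbon. Among the compounds with values here, no measured pair in this set isolates such a change, so there is no direct precedent for its size. The exchange is expected to be small and without a clear direction, most likely within the usual scatter: the step from compound 2 to compound 3 is estimated as a 1.2-fold higher number from compound 2 to compound 3 (0.08 log units; within the scatter) in this assay. For compound 3 the expected value in this assay is 3 nM, with a range from 1 nM to 9 nM.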

Compound 3, inhibition constant: 9.1 nM
Compound 3: middle estimate off by 3.0-fold (0.48 log units), on the low side; the whole stated range lies below it.
By their numbers in this assay, from the lowest: compound 2; then compounds 3 and 1 (each within the scatter of the next).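

Going by these compounds alone, this is the first comparison that isolates a single place: on a carbonyl carbon whose other neighbour is an amide-type nitrogen in a ring, cyclopentyl in place of ethyl gives a 3.6-fold higher number from compound 2 to compound 3 (0.56 log units; beyond the scatter) in this assay. The position therefore responds to the exchange of propanoyl for cyclopentylcarbonyl, and in this one pair the ring-bearing group goes with the higher number. Nothing measured on these compounds accounts for the step.

One pair cannot separate the effect of the ring from that of the added carbons, so a cyclopropyl or an isopropyl on this carbonyl carbon would be informative. On these data alone, whether a dimethylamino group or a methoxymethyl chain is tolerated here also remains open.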